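Cyano in place of methyl on the aromatic ring

This account rests on a few compounds, and the source may have more. Where it says the series, first, only, none or still open, it means among the compounds named here.

Two compounds of the series carry the shared core: compound 1 `O=C(NCc1cccc(Cn2cnc3ccccc32)c1)c1nc2ccccc2[nH]1` and compound 2 `Cc1ccc(C(=O)NCc2cccc(Cn3cnc4ccccc43)c2)cc1`. In an assay for inhibition of Indoleamine 2,3-dioxygenase 1 (Homo sapiens), read by HPLC, with a stated time of 48 h (on this read-out lower numbers stand for stronger inhibition and higher numbers for weaker inhibition), compound 1 gives 407 nM, and in this assay compound 2 gives 327 nM. Among the measured compounds shown here, the single measured step, a 1.2-fold lower number from compound 1 to compound 2 (0.10 log units; within the scatter), lies within the scatter, so compound 2 stands with compound 1 rather than apart from it; neither can be called the more potent of the two.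

Compound 3 `N#Cc1ccc(C(=O)NCc2cccc(Cn3cnc4ccccc43)c2)cc1` is not yet measured. It differs from compound 2 by cyano in place of methyl on an aromatic carbon, the change reading one bond further out as 4-methylphenyl to 4-cyanophenyl. For the measured compounds named here, no measured step touches this aromatic carbon: the one step in hand exchanged the entire group on the carbonyl carbon and stayed within the scatter, so it gives no direction for a change at this ring. Going by the values given here, with no bearing step, no movement beyond the scatter is expected in either direction, and the step expected is a 1.0-fold lower number from compound 2 to compound 3 (0.01 log units; within the scatter). Compound 3 is therefore estimated at 320 nM in this assay, with a range from 120 nM to 850 nM.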

Compound 3, half-maximal inhibitory concentration: 90 nM
For compound 3 the middle estimate is 3.6-fold (0.55 log units) above the measured one; the measured number lies below the stated range.
By their numbers in this assay, from the lowest: compound 3; then compounds 2 and 1 (each within the scatter of the next).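

In this assay, among the compounds shown here, the aromatic carbon para to a large group proves responsive: cyano in place of methyl gives a 3.6-fold lower number from compound 2 to compound 3 (0.56 log units; beyond the scatter) and is the first step to lie beyond the scatter. The group on the carbonyl carbon also proves not to be interchangeable, since the earlier exchange of 1H-benzimidazol-2-yl for 4-methylphenyl stayed within the scatter, whereas 4-cyanophenyl in place of 1H-benzimidazol-2-yl gives a 4.5-fold lower number from compound 1 to compound 3 (0.66 log units; beyond the scatter) and leaves compound 3 with the lowest number of the three. No accompanying data bear on what lies behind either step, so the gain stays an observation about these compounds only.

The three compounds do not show whether the response at this carbon is particular to cyano or would also appear with a primary amide, a carboxylic acid, an amine or a chlorine atom there. Also open, going by these compounds, is whether cyano on another carbon of the same ring would give a step of similar size, or whether a larger group at this carbon, such as a longer chain ending in a nitrile, would keep it.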